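The compounds below may be only part of what the source reports. "The series", "measured", "known", "first", "only" and "open" are said of these compounds alone.

Four compounds share one core and differ only in the aromatic group on a carbon with a double bond to nitrogen. In a functional assay on SW 1116 cells (Homo sapiens) for cytotoxicity, read by MTT assay, with a stated time of 48 h (on this read-out higher numbers stand for weaker inhibition and lower numbers for stronger inhibition), compound 1 (`Cc1ccc(/C=N/NC(=O)CSc2nnc(-c3ccncc3)o2)cc1`) gives 16800 nM. Compound 2 (`O=C(CSc1nnc(-c2ccncc2)o1)N/N=C/c1ccccc1O`) gives 7380 nM, and compound 3 (`O=C(CSc1nnc(-c2ccncc2)o1)N/N=C/c1cc(Cl)ccc1O`) gives 5240 nM. Compound 3 cannot be separated from compound 2, since adding a chloro group gives a 1.4-fold lower number from compound 2 to compound 3 (0.15 log units; within the scatter). Its gap to compound 1 is real but modest: the numbers show a 3.2-fold lower number from compound 1 to compound 3 (0.51 log units; beyond the scatter). The other replacement of the 4-methylphenyl group is similar in size, with a 2.3-fold lower number from compound 1 to compound 2 (0.36 log units; beyond the scatter).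

Compound 4 (`O=C(CSc1nnc(-c2ccncc2)o1)N/N=C/c1ccc(Cl)cc1Cl`) has not yet been measured. It carries 2,4-dichlorophenyl in place of 5-chloro-2-hydroxyphenyl on a carbon with a double bond to nitrogen. Among the measured compounds shown here, no measured step isolates this change. For the measured compounds named here, the nearest guide is compound 1, the only measured compound without a hydroxy group, which stands apart from the others through a 3.2-fold lower number from compound 1 to compound 3 (0.51 log units; beyond the scatter). The chloro step, a 1.4-fold lower number from compound 2 to compound 3 (0.15 log units; within the scatter), offers little further help. A modest move towards a higher number is therefore expected, and the estimated step is a 2.1-fold higher number from compound 3 to compound 4 (0.32 log units; beyond the scatter). For compound 4 the expected value is 11000 nM, with an estimated range of 4000 nM to 28000 nM.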

Compound 4, half-maximal inhibitory concentration: 28900 nM
Estimate against measurement, compound 4: 2.6-fold (0.42 log units) below; the whole stated range lies below it.
By their numbers in this assay, from the lowest: compounds 3 and 2 (each within the scatter of the next); then compounds 1 and 4 (each within the scatter of the next).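

In this assay, putting 2,4-dichlorophenyl in place of 5-chloro-2-hydroxyphenyl gives a 5.5-fold higher number from compound 3 to compound 4 (0.74 log units; beyond the scatter) and a clear loss of activity, and putting it in place of 2-hydroxyphenyl gives a 3.9-fold higher number from compound 2 to compound 4 (0.59 log units; beyond the scatter) in the same direction. Among the compounds shown here, compound 4 cannot be separated from compound 1, with a 1.7-fold higher number from compound 1 to compound 4 (0.24 log units; within the scatter) inside the usual scatter, so the four compounds now fall into two groups: the two with a hydroxy group on the aromatic ring give the lower numbers, the two without it give the higher ones, and no compound here goes against this. Nothing available explains this split in activity.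

For the compounds shown here, the change also adds a second chlorine while it removes the hydroxy group, so no pair here shows the effect of the hydroxy group alone. As far as these compounds go, it also remains open whether a methoxy group or an amine carried by the ring in place of the hydroxy group would give numbers like those of compound 3 or like those of compound 4.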